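The source may report more compounds than this note shows. Statements on the series, on what has been measured and on what is new or still open speak of the compounds shown alone.

Measured so far:
- compound 1 `COc1ccc(NC(=O)COC(=O)/C=C/c2cc(OC)c(OCc3ccc(Cl)c(Cl)c3)c(OC)c2)cc1` — in a functional assay on PC-3 cells (Homo sapiens) for cytotoxicity, read by MTT assay, with a stated time of 72 h (a lower number here means a stronger inhibitor, a higher number a weaker inhibitor), compound 1 gives > 200000 nM, a limit of the assay and not a number.
- compound 2 `O=C(COC(=O)/C=C/c1ccc(O)c(O)c1)NN1CCOCC1` — in this assay compound 2 gives > 200000 nM, again a limit of the assay and not a number.

Compound 2 therefore stands nowhere in particular on the numbers shown: both values shown sit at the limit of > 200000 nM in this assay, at which 2 of the 2 values shown sit, so there is no ordering between compound 1 and compound 2, and no step between measured compounds can be drawn.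

Compound 3 `O=C(COC(=O)/C=C/c1ccc(O)c(O)c1)Nc1ccc(Cl)cc1` follows from compound 2 by one change: 4-chlorophenyl in place of morpholin-4-yl on an amide-type nitrogen. The amide, the ester link and the dihydroxyphenyl acrylate of compound 2 are kept.

Among the compounds with values here, with both measured compounds at the limit, the series gives no measured step to lean on, and no property of the entering or leaving group is recorded here. The expectation for the step from compound 2 to compound 3 is thus none beyond the scatter, with a substantial chance that compound 3 again returns only a limit in this assay; the expected step is an at least 1.3-fold lower number from compound 2 to compound 3 (0.12 log units; that floor lies within the scatter). Compound 3 is estimated at 150000 nM, within 30000 nM to 600000 nM.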

Compound 3, half-maximal inhibitory concentration: 160000 nM
Compound 3: middle estimate off by 1.1-fold (0.03 log units), on the low side; measured number inside the range.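

In this assay, within the data shown here, compound 3 gives 160000 nM, the only value in this assay that is a number and not a limit, so 4-chlorophenyl in place of morpholin-4-yl on an amide-type nitrogen yields a reading inside the measurable range. From the compounds shown here alone, the change gives an at least 1.2-fold lower number from compound 2 to compound 3 (0.09 log units; that floor lies within the scatter); the starting value is a limit of the assay, so only this floor can be stated and the true size of the step stays unknown. Two values in the series still stand at the limit: the limit of > 200000 nM in this assay, at which 2 of the 3 values shown sit.

The compounds shown do not tell whether the chlorine or the aromatic ring itself carries the step, and a plain phenyl group on the same nitrogen would separate the two. Also open, going by these compounds, are how far the number can fall through changes at this position, and whether the dihydroxyphenyl acrylate kept in compound 2 and compound 3 has any part in the reading.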